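A Second Chloro on the Core of Compound 1

The compounds below may be only part of what the source reports. "The series", "measured", "known", "first", "only" and "open" are said of these compounds alone.

compound 1, `ClCc1ccccc1Cn1cnc2ncnc(Cl)c21`: 2080 nM
compound 2, `ClCc1ccc(Cn2cnc3c(Cl)nc(Cl)nc32)cc1`: 1740 nM
compound 3, `ClCc1cccc(Cn2cnc3nc(Cl)nc(Cl)c32)c1`: 1690 nM

Of the compounds shown here, three have so far been measured in a functional assay on RPMI-8226 cells (Homo sapiens) for cytotoxicity, read by sulforhodamine B assay, with a stated time of 48 h; on this read-out lower numbers stand for stronger inhibition of growth and higher numbers for weaker inhibition of growth. Compound 1 gives 2080 nM, the highest of the three numbers. Compound 2 gives 1740 nM, and compound 3 gives 1690 nM. Both gaps to compound 1 lie within the usual scatter of this assay, so the three compounds cannot be told apart on these numbers. Among the compounds with values here, no two of them differ in only one place, so no single structural step has yet been followed from one measured compound to another.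

Compound 4, `ClCc1ccccc1Cn1cnc2nc(Cl)nc(Cl)c21`, differs from compound 1 in one place: chloro in place of hydrogen on an aromatic carbon. Compound 2 and compound 3 each already carry two chloro groups on the shared core, and their numbers sit within the scatter of compound 1. On that basis no step beyond the scatter is expected here, in either direction. The step from compound 1 to compound 4 is therefore expected to be small, a 1.2-fold lower number from compound 1 to compound 4 (0.06 log units; within the scatter). For compound 4 the estimate in this assay is 1800 nM, with an expected range from 900 nM to 3600 nM.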

Compound 4, concentration for 50% growth inhibition: 210 nM
Estimate against measurement, compound 4: 8.6-fold (0.93 log units) above; the whole stated range lies above it.
By their numbers in this assay, from the lowest: compound 4; then compounds 3, 2 and 1 (each within the scatter of the next).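

In this assay, within the data shown here, chloro in place of hydrogen on an aromatic carbon, between two ring nitrogen atoms, gives a 9.9-fold lower number from compound 1 to compound 4 (1.00 log units; beyond the scatter), the first single change that can be followed in this set. It shows that this position on the six-membered aromatic ring with 2 nitrogen is not indifferent to what it carries: one added heavy atom, with no hydrogen-bond donor or acceptor and no net charge, moves the number well beyond the scatter. No measurement at hand accounts for the size of this step.

Among these compounds, compound 2 and compound 3 also carry two chloro groups on the shared core, but no single-change step links either of them to compound 4, so it remains open whether the same change would have the same effect with the chloromethyl group placed differently. The compounds shown also leave open what an amine, a methyl or a methoxy group would do on this same carbon, and therefore whether chloro itself matters or hydrogen simply needs replacing.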